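This account rests on a few compounds, and the source may have more. Where it says the series, first, only, none or still open, it means among the compounds named here.

In a physicochemical assay for solubility, using the shake flask method, in simulated intestinal fluid, measured as kinetic solubility, with a stated time of 2 h, at 25 degrees C, at pH 6.5 (on this read-out higher numbers stand for higher solubility and lower numbers for lower solubility), compound 3 `Cc1noc(-c2nc(C)c3c(c2N)C(=O)N(Cc2ccc(Cl)cc2)C3=O)n1` stands at < 5000 nM, which is a limit of the assay and not a number. Compound 1 `Cc1noc(-c2nc(C)c3c(c2N)C(=O)N(Cc2ccc(-c4ccncc4)cc2)C3=O)n1` gives < 5000 nM, likewise a limit. Compound 2 `Cc1noc(-c2nc(C)c3c(c2N)C(=O)N(CC2CCNCC2)C3=O)n1` gives 160000 nM. Compound 4 `Cc1noc(-c2nc(C)c3c(c2N)C(=O)N(Cc2ccc(Br)cc2)C3=O)n1` carries bromo in place of chloro on an aromatic carbon, para to a large group (bromo in place of chloro on an aromatic carbon). Among the compounds with values here, the only readable step is an at least 32-fold lower number from compound 2 to compound 3 (1.50 log units; beyond the scatter), with 4-chlorophenyl in place of piperidin-4-yl, a much larger change than this one. Chloro in place of pyridin-4-yl gives a step that the two limits leave unreadable from compound 1 to compound 3. Neither step sizes the new change, so no step beyond the scatter is expected in this assay. The expected step is a step that the limit leaves unreadable from compound 3 to compound 4. For compound 4 the estimate is 3000 nM, with an expected range of 1000 nM to 6000 nM.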

Compound 4, solubility: < 5000 nM
Compound 4: no number, only a limit (the forecaster's own chance of this, stated with the estimate: 85%); the middle value lies beyond the limit too.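

In this assay compound 4 gives < 5000 nM, which is a limit of the assay and not a number. The steps to compound 4 from compound 3 and from compound 1 join two limits and cannot be read. The one readable step is an at least 32-fold lower number from compound 2 to compound 4 (1.50 log units; beyond the scatter), with 4-bromophenyl in place of piperidin-4-yl, and bromo now stands with chloro and pyridin-4-yl at one shared limit: the limit of < 5000 nM in this assay, at which 3 of the 4 values shown sit.

Where compound 1, compound 3 and compound 4 truly lie remains open, so chloro and bromo cannot be ranked. Also open, as far as these compounds go, is whether an amine or a carboxylic acid in place of bromo would give a readable number.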